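Methoxy on the pyridyl arm: one change, two cores

The source may hold more compounds than are shown below. What is called first, only, known or untested is meant among the compounds shown, and "the series" means these compounds.

Measured compounds:
compound 1, `O=C(Nc1ccncc1)Nc1cc(-c2cccnc2)cc(C(F)(F)F)c1`: > 300000 nM
compound 2, `COc1ccc(-c2cc(NC(=O)Nc3ccncc3)cc(C(F)(F)F)c2)cn1`: 276000 nM
compound 3, `O=C(Nc1ccncc1)Nc1cc(-c2cccnc2)ccc1OC(F)(F)F`: 39800 nM

The three compounds were tested in a functional assay on A549 cells (Homo sapiens) for inhibition, read by MTT assay, with a stated time of 48 h; a higher number here means a weaker inhibitor, a lower number a stronger inhibitor. For compound 1 the result is a limit of this assay, (the limit of > 300000 nM in this assay, at which 1 of the 3 values shown sits), and not a number. Compound 2 gives 276000 nM in this assay, and compound 3 gives 39800 nM, the lowest of the two numbers recorded.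

Compound 2 differs from compound 1 by methoxy in place of hydrogen on an aromatic carbon. The step that this change made is an at least 1.0-fold lower number from compound 1 to compound 2 (0.03 log units; that floor lies within the scatter), so it is read as no clear movement. Compound 3 and compound 1 share the urea and the pyridyl arm but differ elsewhere in more than one place; the difference between the two cores is not broken down here.

Compound 4, `COc1ccc(-c2ccc(OC(F)(F)F)c(NC(=O)Nc3ccncc3)c2)cn1`, is not yet measured. It differs from compound 3 by methoxy in place of hydrogen on an aromatic carbon, the same change that turned compound 1 into compound 2. Since the earlier step was an at least 1.0-fold lower number from compound 1 to compound 2 (0.03 log units; that floor lies within the scatter), the expectation for compound 4 is a step of about a 1.1-fold lower number from compound 3 to compound 4 (0.06 log units; within the scatter), that is, a number close to that of compound 3. On that basis compound 4 is estimated at 35000 nM in this assay, with a plausible span from 15000 nM to 90000 nM.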

Compound 4, half-maximal inhibitory concentration: > 300000 nM
Compound 4 ended at the assay's limit (the forecaster's own chance of this, stated with the estimate: 5%); at least 8.5-fold (0.93 log units) between middle value and limit.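

In this assay compound 4 gives > 300000 nM, which is a limit of the assay and not a number. Replacing hydrogen with methoxy, which turns pyridin-3-yl into 6-methoxypyridin-3-yl, gave an at least 7.5-fold higher number from compound 3 to compound 4 (0.87 log units; beyond the scatter), so the change that showed no clear movement on the core of compound 1 did not carry over to the core of compound 3, and the effect of this change in the series depends on the core it sits on: the same change on two cores in this assay, an at least 1.0-fold lower number (0.03 log units; that floor lies within the scatter) from compound 1 to compound 2 and an at least 7.5-fold higher number (0.87 log units; beyond the scatter) from compound 3 to compound 4, at least 8.1-fold (0.91 log units) apart, beyond the scatter of two such steps This does not show the true size of either step, or why the two cores part ways, and one pair of cores says nothing about how the change would behave on any further core, as compound 1 and compound 4 both rest at the same limit: the limit of > 300000 nM in this assay, at which 2 of the 4 values shown sit.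

The compounds shown leave open whether the drop on the core of compound 3 is peculiar to methoxy or would also follow from another group in the same place, such as fluorine, methyl or an amine. They also leave open how the change would read on a core with a chlorine or a longer chain in place of the trifluoromethoxy group, where both members of a pair might give numbers clear of the limit.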